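Moving the Benzothiophene Attachment Point on the Acid Core

The source may hold more compounds than are shown below. What is called first, only, known or untested is meant among the compounds shown, and "the series" means these compounds.

The compounds here share an acid-bearing core joined through a benzyl ether to a biaryl arm, and all were tested in an assay on CHO cells for displacement of a labelled ligand from Free fatty acid receptor 1 (Rattus norvegicus), read by scintillation counting, with a stated time of 90 min, in the presence of a further agent that is not named here; on this read-out lower numbers stand for stronger inhibition and higher numbers for weaker inhibition. Compound 1 `Cc1cccc(C)c1-c1cccc(COc2ccc3c(ccn3CC(=O)O)c2)c1`, whose core differs from that of the others, gives > 10000 nM, which is a limit of the assay and not a number. Compound 2 `Cc1ccc2ccccc2c1-c1cccc(COc2ccc3c(c2)OCC3CC(=O)O)c1` gives 470 nM in this assay. Compound 3 `O=C(O)CC1COc2cc(OCc3cccc(-c4csc5ccccc45)c3)ccc21` returns > 10000 nM, again a limit rather than a measured value. Compound 3 therefore stands together with compound 1 at the limit of > 10000 nM in this assay, at which 2 of the 3 values shown sit, while compound 2 alone lies within the measured range.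

Compound 4 `O=C(O)CC1COc2cc(OCc3cccc(-c4ccc5sccc5c4)c3)ccc21` differs from compound 3 in 1-benzothiophen-5-yl in place of 1-benzothiophen-3-yl on an aromatic carbon, meta to a large group. The two have the same atoms, joined differently. Among the measured compounds shown here, no measured step joins this pair, so the expectation rests on compound 2, which gives a number with a fused bicyclic arm on the same core, and on compound 3, which gives only a limit with its own fused arm. The change is expected to bring a gain beyond the scatter, an at least 3.3-fold lower number from compound 3 to compound 4 (0.52 log units; beyond the scatter), while still leaving a weak binder. Compound 4 is estimated at 3000 nM, between 700 nM and 10000 nM, with a real chance that this assay again reports only a limit.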

Compound 4, inhibition constant: > 10000 nM
Compound 4 gave a limit, no number; the forecaster's own chance of this, stated with the estimate: 40%; at least 3.3-fold (0.52 log units) between middle value and limit.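

In this assay compound 4 returns > 10000 nM, a limit and not a number. Compound 3 also stands at a limit, so no step can be read between compound 3 and compound 4: the limit of > 10000 nM in this assay, at which 3 of the 4 values shown sit. The compounds shown leave open whether 1-benzothiophen-5-yl and 1-benzothiophen-3-yl differ at all on this read-out.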